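The compounds below may be only part of what the source reports. "The series", "measured", "known", "first", "only" and "open" are said of these compounds alone.

Of the compounds shown here, two of the shared core have been measured in a functional assay on L5178Y cells (Mus musculus) for inhibition; a lower number here means a less potent compound, a higher number a more potent compound, by a factor of ten per unit of this negative logarithm. Compound 1, `CC1(C)N=C(N)N=C(N)N1c1cccc(C(O)c2ccccc2)c1`, gives 6.41, the lower of the two numbers. Compound 2, `CC1(C)N=C(N)N=C(N)N1c1cccc(OCCOc2ccccc2)c1`, gives 7.34, a value that lies beyond the scatter above that of compound 1. So compound 1 stands at the bottom of what is known so far, with only one neighbour for comparison.

Compound 3, `CC1(C)N=C(N)N=C(N)N1c1cccc(S(N)(=O)=O)c1`, has not yet been tested in this assay. It differs from compound 1 in one place: sulfamoyl in place of hydroxy(phenyl)methyl on an aromatic carbon. Among the measured compounds shown here, no measured pair in this set shows such a change, so any expectation rests on the bare structures. The larger group of compound 2 gave the higher number; the sulfamoyl group is the smaller of the two groups here, and the expected step of a number 0.51 log units lower from compound 1 to compound 3 (beyond the scatter) is therefore downward, beyond the scatter. Compound 3 is expected to give 5.9, within a range from 5.1 to 6.7.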

Compound 3, logarithm of the reciprocal of the active concentration, log(1/C): 5.61
For compound 3 the middle estimate is 0.29 log units above the measured one, within the range that was stated.
By their numbers in this assay, from the lowest: compound 3; then compound 1; then compound 2.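

In this assay, sulfamoyl in place of hydroxy(phenyl)methyl on this aromatic carbon gives a number 0.80 log units lower from compound 1 to compound 3 (beyond the scatter), the first step read directly at this position. It shows that the number depends on the group held here, meta to a large group: the change removes a six-membered aromatic ring and leaves a group with no ring, and the number falls beyond the scatter. Nothing measured in this set speaks to the reason for this fall.

The compounds shown leave open whether the fall goes with the loss of the aromatic ring or with the sulfamoyl group itself. An amine or a carboxylic acid on the same carbon, set against a plain phenyl or benzyl group there, would begin to separate these two readings.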